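A few compounds are considered here, and "the series" means these few. Any claim that something is new, unique, unknown or untested is made for them only; others in the source may bear on it.

Measured so far:
compound 1 `O=C1NCCC12CCN(c1c(Cl)cncc1-c1cccs1)CC2`, 480 nM in a functional assay on MV4-11 cells (Homo sapiens) for inhibition, read by resazurin assay, with a stated time of 72 h; on this read-out higher numbers stand for weaker inhibition of growth and lower numbers for stronger inhibition of growth
compound 2 `Cc1ccc(-c2cncc(Cl)c2N2CCC3(CCNC3=O)CC2)s1`, 650 nM in this assay
compound 3 `O=Cc1ccc(-c2cncc(Cl)c2N2CCC3(CCNC3=O)CC2)s1`, 750 nM in this assay

All three share the same core; compound 3 differs from compound 1 by formyl in place of hydrogen on an aromatic carbon. Compound 2 differs from compound 1 by methyl in place of hydrogen on an aromatic carbon, and this gave a 1.4-fold higher number from compound 1 to compound 2 (0.13 log units; within the scatter). Compound 3 against compound 1 gave a 1.6-fold higher number from compound 1 to compound 3 (0.19 log units; within the scatter), and compound 3 against compound 2 gave a 1.2-fold higher number from compound 2 to compound 3 (0.06 log units; within the scatter), so the three values lie close together.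

Compound 4 `Cc1cc(-c2cncc(Cl)c2N2CCC3(CCNC3=O)CC2)sc1C=O` is not yet measured in this assay. It differs from compound 3 by methyl in place of hydrogen on an aromatic carbon. This is the same kind of change as from compound 1 to compound 2, but the place differs: there the methyl entered next to the ring sulfur, here it enters next to the ring atom that bears a formyl group, two ring bonds from the ring sulfur. Beside a 1.4-fold higher number from compound 1 to compound 2 (0.13 log units; within the scatter), a step of about a 1.3-fold higher number from compound 3 to compound 4 (0.10 log units; within the scatter) is expected, because the earlier methyl gave a 1.4-fold higher number from compound 1 to compound 2 (0.13 log units; within the scatter) and only one such case is known. Compound 4 is estimated at 950 nM, within 400 nM to 2300 nM.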

Compound 4, concentration for 50% growth inhibition: 2530 nM
Estimate against measurement, compound 4: 2.7-fold (0.43 log units) below; the whole stated range lies below it.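

In this assay, methyl in place of hydrogen gives a 3.4-fold higher number from compound 3 to compound 4 (0.53 log units; beyond the scatter), and the whole 5-formyl-4-methylthiophen-2-yl group gives a 3.9-fold higher number from compound 2 to compound 4 (0.59 log units; beyond the scatter) and a 5.3-fold higher number from compound 1 to compound 4 (0.72 log units; beyond the scatter). Going by these compounds alone, the two methyl steps cannot be told apart: the same change on two cores in this assay, a 1.4-fold higher number (0.13 log units; within the scatter) from compound 1 to compound 2 and a 3.4-fold higher number (0.53 log units; beyond the scatter) from compound 3 to compound 4, 2.5-fold (0.40 log units) apart, within the scatter of two such steps So the series shows no firm dependence of this change on the core, but with only two pairs, and the methyl at a different place in each, it does not show that the step carries over either.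

Open, going by these compounds, is whether 4-methylthiophen-2-yl without the formyl group would show the same step. Also open, on these data alone, is how compound 4 would respond to a carboxylic acid or an aminomethyl group in place of formyl.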